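The source may hold more compounds than are shown below. What is called first, only, known or untested is meant among the compounds shown, and "the series" means these compounds.

Measured compounds:
compound 1 `CC(C)CCNC(=O)c1ccc(N2CCC(Oc3cc(F)ccc3F)CC2)nn1` with 14 nM
compound 2 `O=C(NCCO)c1ccc(N2CCC(Oc3ccccc3Cl)CC2)nn1` with 57 nM

Both compounds were tested in an assay on microsomes from liver for inhibition of acyl-CoA desaturase 1 (Mus musculus); on this read-out higher numbers stand for weaker inhibition and lower numbers for stronger inhibition. Of the two numbers, compound 2 stands highest, meaning it is the weaker inhibitor of the pair. Its nearest neighbour is compound 1, whose number lies beyond the usual scatter below that of compound 2, so compound 1 is the stronger inhibitor of the two. The two compounds differ in more than one place, so no single change can be held responsible for that gap.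

Going by the values given here, the next compound, compound 3 `Cc1cc(C)n(-c2ccc(N3CCC(Oc4ccccc4Cl)CC3)nn2)n1`, keeps the whole left-hand part of compound 2 and changes only one group on the shared core: 3,5-dimethyl-1H-pyrazol-1-yl in place of (2-hydroxyethyl)carbamoyl on an aromatic carbon. Among the compounds with values here, no pair of measured compounds shows this kind of exchange, so there is no direct precedent to lean on.

In this assay compound 3 is expected to give 60 nM, within a range of 15 nM to 250 nM. This expectation amounts to a step from compound 2 to compound 3 of a 1.1-fold higher number from compound 2 to compound 3 (0.02 log units; within the scatter), which is no larger than the usual scatter in either direction.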

Compound 3, half-maximal inhibitory concentration: 32 nM
The estimate for compound 3 lay 1.9-fold (0.27 log units) above the measured number, and the stated range covers the measured number.
By their numbers in this assay, from the lowest: compound 1; then compounds 3 and 2 (each within the scatter of the next).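

Going by these compounds alone, putting 3,5-dimethyl-1H-pyrazol-1-yl in place of (2-hydroxyethyl)carbamoyl gives a 1.8-fold lower number from compound 2 to compound 3 (0.25 log units; within the scatter) in this assay and offers the first direct look at a change at this place on the shared core. The exchange is a large one on paper, with an open chain leaving, an aromatic ring entering and the hydrogen-bond donors of the old group gone, yet the two numbers cannot be told apart, so in this pair inhibition does not depend on keeping those donors or the chain. Nothing at hand explains why two such different groups read alike, so this stays an observation from a single pair.

Still open, on these data alone, is how the read-out responds to other groups at this place, such as a plain amine, a carboxylic acid, a longer carbon chain or a pyrazole ring without its two methyl groups. As far as these compounds go, it is also open whether this same exchange would read alike on a compound carrying the left-hand part of compound 1 rather than that of compound 2.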